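The source may hold more compounds than are shown below. What is called first, only, known or untested is meant among the compounds shown, and "the series" means these compounds.

Three compounds of the series carry numbers in a functional assay on PC-3 cells (Homo sapiens) for antiproliferative activity, read by MTT assay, with a stated time of 24 h; on this read-out lower numbers stand for stronger inhibition and higher numbers for weaker inhibition. Compound 1 `O=C1O/C(=C\Cn2cc(C3=CCCCC3)nn2)C(OCc2ccccc2)=C1OCc1ccccc1` gives 55600 nM, compound 2 `O=C1NC(O)(CCn2cc(C3=CCCCC3)nn2)C(OCc2ccccc2)=C1OCc1ccccc1` gives 67200 nM, and compound 3 `CCCc1cn(CCC2(O)C(OCc3ccccc3)=C(OCc3ccccc3)C(=O)N2CCC)nn1` gives 35000 nM. Compound 2 holds the highest of the three numbers, yet its gap to compound 1 and its gap to compound 3 each lie within the scatter, so no order among the three can be read from them. Compound 4 `O=C1NC(O)(CCn2cc(-c3ccccc3)nn2)C(OCc2ccccc2)=C1OCc1ccccc1` is the next compound to be measured in this assay; it differs from compound 2 by phenyl in place of cyclohex-1-en-1-yl on an aromatic carbon. For the measured compounds named here, with no step between measured compounds at hand, the expectation is a 1.1-fold lower number from compound 2 to compound 4 (0.05 log units; within the scatter), a change not beyond the scatter in either direction. Compound 4 is therefore estimated at 60000 nM, between 25000 nM and 150000 nM.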

Compound 4, half-maximal inhibitory concentration: > 100000 nM
Compound 4 ended at the assay's limit (the forecaster's own chance of this, stated with the estimate: 20%); middle value at least 1.6-fold (0.22 log units) from the limit.
By their numbers in this assay, from the lowest: compounds 3, 1 and 2 (each within the scatter of the next). At a limit, above all of these: compound 4.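

In this assay compound 4 gives > 100000 nM, which is a limit of the assay and not a number: the limit of > 100000 nM in this assay, at which 1 of the 4 values shown sits. Phenyl in place of cyclohex-1-en-1-yl gives the first step at this aromatic carbon, an at least 1.4-fold higher number from compound 2 to compound 4 (0.17 log units; that floor lies within the scatter), so the series now has one direct comparison at this position. Going by these compounds, the true size of the step stays unknown, and its floor does not separate the two groups.

Open, on these data alone, is how far past the limit the phenyl compound lies. Also open, as far as these compounds go, is what an amine or a carboxylic acid on this aromatic carbon would give.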